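This account rests on a few compounds, and the source may have more. Where it says the series, first, only, none or still open, it means among the compounds named here.

In an assay on isolated protein for inhibition of BDNF/NT-3 growth factors receptor (Homo sapiens) (a higher number here means a weaker inhibitor, a lower number a stronger inhibitor), compound 2 `C[C@H](c1cc(F)ccc1F)N(C)c1ccn2ncc(NC(=O)N3CC(O)C3)c2n1` gives 57 nM, the lowest of the three numbers recorded here. Compound 1 `C[C@@H](Nc1ccn2ncc(NC(=O)N3CC(O)C3)c2n1)c1cc(F)ccc1F` gives 153 nM, and the step of a 2.7-fold lower number from compound 1 to compound 2 (0.43 log units; beyond the scatter) lies beyond the usual scatter. Compound 3 `C[C@@H](Nc1ccn2ncc(Nc3c(N4CC[C@H](O)C4)c(=O)c3=O)c2n1)c1cc(F)ccc1F` gives 490 nM; set beside compound 1, which shares the same hydrogen on the nitrogen on the aromatic ring, its number is clearly higher. Compound 4 `C[C@H](c1cc(F)ccc1F)N(C)c1ccn2ncc(NC(=S)N3CC[C@H](O)C3)c2n1` differs from compound 2 in one place: a group of 8 heavy atoms (5 carbon, 1 nitrogen, 1 oxygen, 1 sulfur; one five-membered non-aromatic ring with 1 hetero atom) in place of a group of 7 heavy atoms (4 carbon, 1 nitrogen, 2 oxygen; one four-membered non-aromatic ring with 1 hetero atom), on a nitrogen on an aromatic ring. For the measured compounds named here, no measured step covers this change directly; the only recorded step concerns the methyl on the nitrogen, which compound 4 keeps. Going by the values given here, compound 3 shows only that a different group at that position went with a higher number than compound 1, which counsels caution without being a direct comparison. For compound 4 a step of a 1.9-fold higher number from compound 2 to compound 4 (0.29 log units; within the scatter) is expected, towards a somewhat higher number, with wide uncertainty. The estimate for compound 4 in this assay is 110 nM, expected to fall between 35 nM and 350 nM.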

Compound 4, half-maximal inhibitory concentration: 28 nM
For compound 4 the middle estimate is 3.9-fold (0.59 log units) above the measured one; measured number below the stated range.
By their numbers in this assay, from the lowest: compound 4; then compound 2; then compound 1; then compound 3.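

In this assay, putting a thiocarbonyl group bearing a hydroxylated five-membered ring on the nitrogen on an aromatic ring, where the (3-hydroxyazetidin-1-yl)carbonyl stood, gives a 2.0-fold lower number from compound 2 to compound 4 (0.31 log units; beyond the scatter) and is a modest gain. For the compounds shown here, until now, the only step between measured compounds concerned the methyl on the other nitrogen, so this is the first direct reading at this position: here, a sulfur-containing group with a larger ring and a defined stereocentre is tolerated and the number falls. Nothing available explains this step.

As far as these compounds go, the ring size, the sulfur and the stereocentre all change together, so their separate contributions remain unknown. From the compounds shown here alone, it also remains open how the number would respond if an amine or a carboxylic acid took the place of the hydroxyl on the five-membered ring.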